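The source may hold more compounds than are shown below. What is called first, only, known or untested is meant among the compounds shown, and "the series" means these compounds.

Of the compounds shown here, three built on a shared core have so far been measured in a physicochemical assay for acid dissociation. Compound 1 `COc1cccc(CNCCCNc2ccnc3cc(C4CCCCC4)ccc23)c1O` gives 9.47 in this assay, compound 2 `CC(C)Cc1ccc2c(NCCCNCc3ccco3)ccnc2c1` gives 9.47 and compound 3 `COc1ccc(Oc2ccc3c(NCCCNCc4cc(F)ccc4OC)ccnc3c2)cc1` gives 9.28. Compound 2 thus stands level with compound 1 at the digits shown, and compound 3 differs from compound 2 only by an amount within the usual scatter, so the three numbers cannot be ordered. Compound 4 `COc1ccc(-c2ccc3c(NCCCNCc4ccco4)ccnc3c2)cc1` awaits measurement. It differs from compound 2 by 4-methoxyphenyl in place of isobutyl on an aromatic carbon. Because compound 1 at 9.47 and compound 3 at 9.28 sit so close to compound 2 despite different groups at this place, no step beyond the scatter is expected. Compound 4 is therefore estimated at 9.4, within 9.1 to 9.7. The expected step is a number 0.07 log units lower from compound 2 to compound 4 (within the scatter).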

Compound 4, acid dissociation constant: 9.47
The estimate for compound 4 lay 0.07 log units below the measured number; the range from low to high includes it.
By their numbers in this assay, from the lowest: compounds 3, 1, 2 and 4 (each within the scatter of the next).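

In this assay, among these compounds, 4-methoxyphenyl in place of isobutyl on this aromatic carbon gives no change at the digits printed from compound 2 to compound 4 (within the scatter), the first comparison here of compounds differing in one place. At this position, therefore, 8 heavy atoms replace 4, and an aromatic ring and a hydrogen-bond acceptor enter, with no step beyond the scatter. Nothing available accounts for this result. As far as these compounds go, whether an amine or a carboxylic acid at this place would also leave the number within the scatter remains open. One step also cannot show whether the same holds with other groups elsewhere on the shared core.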